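A few compounds are considered here, and "the series" means these few. Any claim that something is new, unique, unknown or untested is made for them only; others in the source may bear on it.

Two compounds from this series have been run in a functional assay on Raji cells (Homo sapiens) for cytotoxicity, read by CCK-8 assay, with a stated time of 24 h; on this read-out higher numbers stand for weaker inhibition and lower numbers for stronger inhibition. Compound 1 `C=CC(=O)N1C(=O)CC(C)Sc2ccccc21` gives 837000 nM in this assay. Compound 2 `C=CC(=O)N1C(=O)CC(c2ccc(Br)cc2)Sc2ccccc21` gives 51300 nM in this assay, the lower of the two numbers, and the measured step to it is a 16-fold lower number from compound 1 to compound 2 (1.21 log units; beyond the scatter). Compound 3 `C=CC(=O)N1C(=O)CC(c2ccccc2)Sc2ccccc21` has not yet been tested. It differs from compound 2 in one place: hydrogen in place of bromo on an aromatic carbon, a change that reads as 4-bromophenyl to phenyl when cut one bond further out. Among the compounds with values here, no measured step isolates this change; the only step available, a 16-fold lower number from compound 1 to compound 2 (1.21 log units; beyond the scatter), brings in the whole 4-bromophenyl group at once, so it bears on the change only indirectly. Compound 3 is therefore expected to give a number somewhat higher than compound 2, and the expected step is a 2.3-fold higher number from compound 2 to compound 3 (0.37 log units; beyond the scatter). The estimate for compound 3 in this assay is 120000 nM, within a range from 40000 nM to 400000 nM.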

Compound 3, half-maximal inhibitory concentration: 74100 nM
Compound 3: the middle estimate sits 1.6-fold (0.21 log units) above what was measured; the measured number falls inside the stated range.
By their numbers in this assay, from the lowest: compounds 2 and 3 (each within the scatter of the next); then compound 1.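

In this assay, removing the bromo leaves the number within the scatter, with a 1.4-fold higher number from compound 2 to compound 3 (0.16 log units; within the scatter), so this para position on the phenyl ring shows no measurable dependence on bromo in this pair. The change from methyl to unsubstituted phenyl on the saturated ring carbon is by itself large, with an 11-fold lower number from compound 1 to compound 3 (1.05 log units; beyond the scatter), which shows that the large gain seen earlier does not require the bromo. No measured evidence is available to explain either result.

The compounds shown leave open whether a methoxy group or an amine at the same para position would move the number beyond the scatter. They also leave open whether a longer chain, such as hexyl, on the saturated ring carbon could match phenyl.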